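The source may report more compounds than this note shows. Statements on the series, on what has been measured and on what is new or still open speak of the compounds shown alone.

In a functional assay on MDA-MB-231 cells (Homo sapiens) for antiproliferative activity, read by sulforhodamine B assay (on this read-out higher numbers stand for weaker inhibition of growth and lower numbers for stronger inhibition of growth), compound 1 `CC(C)CCCOc1cccc(O)c1C(=O)/C=C/c1ccc(O)cc1` gives 3480 nM. Compound 2 `CC(C)=CCOc1cccc(O)c1C(=O)/C=C/c1ccc(O)cc1` reads > 30000 nM, which is a limit. Compound 3 `CCCCOc1cccc(O)c1C(=O)/C=C/c1ccc(O)cc1` reads > 30000 nM, also a limit, so it stands at the limit of > 30000 nM in this assay, at which 2 of the 3 values shown sit, and has no exact number. Compound 4 `O=C(/C=C/c1ccc(O)cc1)c1c(O)cccc1OCCC1CCCC1` differs from compound 3 by cyclopentyl in place of ethyl on a saturated chain carbon, two bonds along the chain from an oxygen on an aromatic ring, turning butoxy into 2-cyclopentylethoxy. The measured guides are an at least 8.6-fold higher number from compound 1 to compound 3 (0.93 log units; beyond the scatter) and an at least 8.6-fold higher number from compound 1 to compound 2 (0.93 log units; beyond the scatter); both lie beyond the scatter. Only compound 1 has a measured number, and its larger chain end goes with stronger inhibition of growth. Compound 4 also gains carbon at the chain end, so a move towards lower numbers is expected, though it may stay at the limit. The expected step is an at least 5.0-fold lower number from compound 3 to compound 4 (0.69 log units; beyond the scatter). For compound 4, the estimated value is 6000 nM, with a range of 1500 nM to 30000 nM.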

Compound 4, concentration for 50% growth inhibition: 3340 nM
Beside the measured number, compound 4's estimate is 1.8-fold (0.25 log units) above it; measured number inside the range.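

In this assay, a cyclopentyl ring in place of ethyl gives the first clear gain on a short chain, an at least 8.9-fold lower number from compound 3 to compound 4 (0.95 log units; beyond the scatter), and the change from the 2-methylprop-1-en-1-yl end gives an at least 8.9-fold lower number from compound 2 to compound 4 (0.95 log units; beyond the scatter). Both steps start from a limit, not a number: the limit of > 30000 nM in this assay, at which 2 of the 4 values shown sit. The ring and the open isobutyl end cannot be told apart at this place, with a 1.0-fold lower number from compound 1 to compound 4 (0.02 log units; within the scatter), so a cyclic chain end and a branched one both fit here.

The compounds shown leave open whether a cyclohexyl end or a longer chain would lower the number further. They also leave open how an amine at the chain end would read.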